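Taking the side chain off compound 2

The source may report more compounds than this note shows. Statements on the series, on what has been measured and on what is new or still open speak of the compounds shown alone.

Compound 1 `CC(C)(C)C1=CC(=O)C=C(NCCC(=O)O)C1=O` – 28400 nM
Compound 2 `CC(C)(C)C1=CC(=O)C=C(NCC(=O)O)C1=O` – 34300 nM
Compound 3 `CC1=CCC[C@H]2[C@](C)(CC3=CC(=O)C=C(NCCC(=O)O)C3=O)[C@@H](C)CC[C@]12C` – 20200 nM
Compound 4 `CC(C)(C)C1=CC(=O)C=CC1=O` – not yet measured

These values all come from a functional assay on Fem-X cells (Homo sapiens) for cytotoxicity, read by MTT assay, with a stated time of 72 h (on this read-out higher numbers stand for weaker inhibition and lower numbers for stronger inhibition), and they sit close together. Compound 2 with 34300 nM lies within the usual scatter of both compound 1 and compound 3, so it holds no distinct place among them.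

The change to compound 4 is much larger than any seen so far (hydrogen in place of (carboxymethyl)amino on a double-bonded ring carbon): hydrogen in place of (carboxymethyl)amino on a double-bonded ring carbon. Within the data shown here, only one measured step bears on this. With carboxy in place of carboxymethyl on a saturated chain carbon, it is a 1.2-fold higher number from compound 1 to compound 2 (0.08 log units; within the scatter) and it only trims the chain. Among the measured compounds shown here, no measured compound lacks the chain altogether, so the data do not fix the direction of the change. A modest move towards a lower number is a cautious guess. The step expected is a 2.3-fold lower number from compound 2 to compound 4 (0.36 log units; beyond the scatter) and it remains a rough estimate. Compound 4 is estimated at 15000 nM with 4000 nM and 40000 nM as the ends of its range.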

Compound 4, half-maximal inhibitory concentration: 41600 nM
Beside the measured number, compound 4's estimate is 2.8-fold (0.44 log units) below it, outside the stated range (above it).
By their numbers in this assay, from the lowest: compounds 3, 1, 2 and 4 (each within the scatter of the next, the first and the last beyond it).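

In this assay, hydrogen in place of (carboxymethyl)amino gives a 1.2-fold higher number from compound 2 to compound 4 (0.08 log units; within the scatter), and hydrogen in place of (2-carboxyethyl)amino gives a 1.5-fold higher number from compound 1 to compound 4 (0.17 log units; within the scatter). The earlier step only trimmed the chain, whereas these two steps take it off this double-bonded ring carbon altogether. Among these three compounds with a tert-butyl group, then, the read-out stays within the scatter whether the chain is present or absent, so the chain and its carboxylic acid are not needed for this level of cytotoxicity. Nothing available here explains this result.

On these data alone, it remains open whether a plain amine, a methyl group or a much longer chain on this carbon would shift the number beyond the scatter. As far as these compounds go, it is also open whether replacing the chain with hydrogen would give the same result on the core of compound 3.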